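Cyclopentyl in place of 2-chlorophenyl on a carbonyl carbon

This account rests on a few compounds, and the source may have more. Where it says the series, first, only, none or still open, it means among the compounds named here.

Compound 1 `O=C(c1ccccc1F)N1CCN(c2nc(=O)c3cc(C(F)(F)F)cc([N+](=O)[O-])c3s2)CC1`: 3.1 ug/mL
Compound 2 `CC(C)(C)C(=O)N1CCN(c2nc(=O)c3cc(C(F)(F)F)cc([N+](=O)[O-])c3s2)CC1`: 5.87 ug/mL
Compound 3 `O=C(c1ccccc1Cl)N1CCN(c2nc(=O)c3cc(C(F)(F)F)cc([N+](=O)[O-])c3s2)CC1`: 8.18 ug/mL

These three numbers come from a physicochemical assay for solubility, read by HPLC; on this read-out lower numbers stand for lower solubility and higher numbers for higher solubility. Compound 3 gives 8.18 ug/mL, the highest of the three, with a 1.4-fold higher number from compound 2 to compound 3 (0.14 log units; within the scatter) and a 2.6-fold higher number from compound 1 to compound 3 (0.42 log units; beyond the scatter). Compound 4 `O=C(C1CCCC1)N1CCN(c2nc(=O)c3cc(C(F)(F)F)cc([N+](=O)[O-])c3s2)CC1` has not yet been measured. It differs from compound 3 in one group: cyclopentyl in place of 2-chlorophenyl on a carbonyl carbon.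

For the measured compounds named here, no measured step makes this exact exchange. Going by the values given here, the closest evidence is compound 2, the only measured compound without an aromatic ring in that place, and the step to compound 3 was small: a 1.4-fold higher number from compound 2 to compound 3 (0.14 log units; within the scatter). The step of a 1.9-fold higher number from compound 1 to compound 2 (0.28 log units; within the scatter) was similarly small. Among the compounds with values here, the one larger step, a 2.6-fold higher number from compound 1 to compound 3 (0.42 log units; beyond the scatter), is a change of chloro for fluoro on an aromatic carbon, which is a different kind of exchange and only modest in size. A slightly lower number is therefore expected for compound 4, but no change beyond the scatter in this assay. The expected step is a 1.4-fold lower number from compound 3 to compound 4 (0.13 log units; within the scatter). For compound 4 the estimated value is 6 ug/mL, with an expected range from 2.5 ug/mL to 14 ug/mL.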

Compound 4, solubility: 5.34 ug/mL
For compound 4 the middle estimate is 1.1-fold (0.05 log units) above the measured one, within the range that was stated.
By their numbers in this assay, from the lowest: compounds 1, 4, 2 and 3 (each within the scatter of the next, the first and the last beyond it).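

In this assay, cyclopentyl in place of 2-chlorophenyl on the carbonyl carbon gives a 1.5-fold lower number from compound 3 to compound 4 (0.19 log units; within the scatter), so at this position a five-membered non-aromatic ring of carbon only can take the place of a six-membered aromatic ring without a step beyond the scatter. The two other exchanges at the same place read alike: cyclopentyl for tert-butyl gives a 1.1-fold lower number from compound 2 to compound 4 (0.04 log units; within the scatter), and cyclopentyl for 2-fluorophenyl gives a 1.7-fold higher number from compound 1 to compound 4 (0.24 log units; within the scatter), which leaves a 2.6-fold higher number from compound 1 to compound 3 (0.42 log units; beyond the scatter) as the only step beyond the scatter among these four compounds. Nothing available accounts for the size of any of these steps.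

The compounds shown leave open whether an amine, a morpholine or a carboxylic acid on this carbonyl carbon would give a number beyond the scatter of these four. They also leave open whether steps this small would hold if a nitrile stood in place of the trifluoromethyl group on the shared core.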